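The source may report more compounds than this note shows. Statements on the series, on what has been measured and on what is new or still open speak of the compounds shown alone.

Measured so far in an ADME assay on cells (Homo sapiens) for cytotoxicity; a higher number here means that more compound is tolerated, a lower number that less compound is tolerated:
compound 1, `CCc1nc(-c2ccc(OCCC(C)CCN3CCN(c4ccncc4)C3=O)cc2)no1` — > 25000 nM.
compound 2, `Cc1nc(-c2ccc(OCCC(C)CCN3CCN(c4ccncc4)C3=O)cc2)no1` — > 6250 nM.
compound 3, `O=C1N(Cc2ccc(COc3ccc(-c4ccc(Cl)cc4)cc3)cc2)CCN1c1ccncc1` — > 1250 nM.

For compound 1 the value in this assay is a limit of the assay, (the limit of > 25000 nM in this assay, at which 1 of the 3 values shown sits), not a number. For compound 2 the value in this assay is likewise a limit, (the limit of > 6250 nM in this assay, at which 1 of the 3 values shown sits), so compound 2 stands only at a limit, as do the two other compounds shown. For compound 3 the value in this assay is again a limit, (the limit of > 1250 nM in this assay, at which 1 of the 3 values shown sits). Within the data shown here, the only step between measured compounds, a step that the two limits leave unreadable from compound 1 to compound 2, cannot be read since both of its ends are limits.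

Compound 4, `CCCc1nc(-c2ccc(OCCC(C)CCN3CCN(c4ccncc4)C3=O)cc2)no1`, has not yet been measured in this assay. It differs from compound 2 by ethyl in place of hydrogen on a saturated chain carbon bound to an aromatic carbon. Among the measured compounds shown here, the step that bears on this change is a step that the two limits leave unreadable from compound 1 to compound 2, and its size is not readable, so no measured step gives a size in this assay for the move from compound 2 to compound 4. Because compound 1 gives > 25000 nM in this assay with ethyl at the same place, compound 4 is expected to be tolerated at least as far as the limits seen, and its step that the limit leaves unreadable from compound 2 to compound 4 is estimated to stay within a limit rather than a number. Compound 4 is therefore estimated at 30000 nM in this assay, with a range from 6250 nM to 100000 nM.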

Compound 4, half-maximal cytotoxic concentration: > 12500 nM
Compound 4: no number, only a limit; the forecaster's own chance of this, stated with the estimate: 80%; the middle value is on the limit's open side.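

In this assay compound 4 gives > 12500 nM, a limit of the assay and not a number. The steps linking compound 4 to compound 2 and to compound 1 have limits at both ends, and neither can be read. The compounds shown leave open where any half-maximal cytotoxic concentration lies, and whether the change from methyl to ethyl to propyl alters it at all.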